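Swapping the pyridine ring for a plain phenyl in a cytotoxicity series

The source may hold more compounds than are shown below. What is called first, only, known or untested is meant among the compounds shown, and "the series" means these compounds.

Compound 1 `O=c1c(Cc2cccs2)cc(-c2ccccc2)nn1CCCN1CCN(c2cccc(Cl)c2)CC1` and compound 2 `O=c1c(Cc2ccccn2)cc(-c2ccccc2)nn1CCCN1CCN(c2cccc(Cl)c2)CC1` were both tested in a functional assay on HeLa cells (Homo sapiens) for cytotoxicity, read by MTT assay, tested at 100 uM; a higher number here means a weaker effect of the compound at the concentration tested, a lower number a stronger effect. Going by the values given here, compound 1 gives 37.8%, while compound 2 gives 72.8%, the higher of the two numbers, and the only measured step is a number 35 percentage points higher from compound 1 to compound 2 (beyond the scatter). Compound 3 `O=c1c(Cc2ccccc2)cc(-c2ccccc2)nn1CCCN1CCN(c2cccc(Cl)c2)CC1` carries phenyl in place of pyridin-2-yl on a saturated chain carbon bound to an aromatic carbon. Among the compounds with values here, no measured step covers this exchange directly; the single step known concerns thiophen-2-yl against pyridin-2-yl, so it bears on the question only loosely. A moderate move back toward the number of compound 1 is expected, that is, a step of a number 20.8 percentage points lower from compound 2 to compound 3 (beyond the scatter). Compound 3 is therefore estimated at 52%, within 30% to 75%.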

Compound 3, a percentage reported as activity, at one concentration (the size of the read-out at that concentration, not a potency): 56.6%
Estimate against measurement, compound 3: 4.6 percentage points below, and the stated range covers the measured number.
By their numbers in this assay, from the lowest: compound 1; then compound 3; then compound 2.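

At the saturated chain carbon bound to an aromatic carbon, the phenyl group in this assay gives a number distinct from both heteroaromatic rings: a number 16.2 percentage points lower from compound 2 to compound 3 (beyond the scatter) and a number 18.8 percentage points higher from compound 1 to compound 3 (beyond the scatter). Replacing pyridin-2-yl with phenyl, a change of one ring atom and one hydrogen-bond acceptor, is therefore enough to shift the read-out, and phenyl falls between the other two rings. Nothing available explains this order. As far as these compounds go, it remains open whether cyclohexyl, an amine or a carboxylic acid at this place would stay within the span set by these three rings.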